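The source may report more compounds than this note shows. Statements on the series, on what has been measured and on what is new or still open speak of the compounds shown alone.

Compound 2 `CCCc1nc(-c2ccccc2)c(CNCCCN2CCN(c3cccc(C)c3C)CC2)o1` stands second highest of the three numbers in an assay on HEK293 cells for inhibition of Voltage-dependent T-type calcium channel subunit alpha-1G (Homo sapiens), read by patch clamp (a higher number here means a weaker inhibitor, a lower number a stronger inhibitor), where compound 2 gives 1780 nM. Compound 3 `CCCc1nc(-c2ccccc2)c(CNCCN2CCN(c3cccc(C)c3C)CC2)o1` sits within the scatter of it, as compound 3 gives 1710 nM. Compound 1 `CCCc1nc(-c2ccccc2)c(CNCCN2CCN(c3ccccc3Cl)CC2)o1` carries the highest number; compound 1 gives 4370 nM. Compound 4 `CCCc1nc(-c2ccccc2)c(CNCCCN2CCN(c3ccc(Cl)cc3)CC2)o1` has not yet been measured in this assay. Its change from compound 2 is 4-chlorophenyl in place of 2,3-dimethylphenyl on an amine nitrogen in a ring. Among the measured compounds shown here, the one measured step that bears on it is a 2.6-fold lower number from compound 1 to compound 3 (0.41 log units; beyond the scatter), where 2,3-dimethylphenyl took the place of 2-chlorophenyl on an amine nitrogen in a ring; compound 4 goes the other way, back to a chlorophenyl, though as 4-chlorophenyl rather than 2-chlorophenyl, so the match is loose. A modest rise in the number, a 2.0-fold higher number from compound 2 to compound 4 (0.29 log units; within the scatter), is therefore expected. Compound 4 is estimated at 3500 nM, with a range from 1500 nM to 8000 nM.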

Compound 4, half-maximal inhibitory concentration: 1310 nM
The estimate for compound 4 lay 2.7-fold (0.43 log units) above the measured number; measured number outside the range, below it.
By their numbers in this assay, from the lowest: compounds 4, 3 and 2 (each within the scatter of the next); then compound 1.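

In this assay, 4-chlorophenyl in place of 2,3-dimethylphenyl on an amine nitrogen in a ring gives a 1.4-fold lower number from compound 2 to compound 4 (0.13 log units; within the scatter), so the two groups cannot be told apart here. The earlier 2.6-fold lower number from compound 1 to compound 3 (0.41 log units; beyond the scatter) therefore does not carry over to every chlorophenyl at this position. No evidence is available to explain this result.

Open, from the compounds shown here alone, is whether 3-chlorophenyl, 4-methoxyphenyl or a pyridine ring on the same nitrogen would move the number beyond the scatter. Also open, going by these compounds, is whether 2-chlorophenyl would behave as 4-chlorophenyl does on the chain of compound 4.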